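Swapping Methylsulfonyl for Propanoyl on a Ring Nitrogen

The source may hold more compounds than are shown below. What is called first, only, known or untested is meant among the compounds shown, and "the series" means these compounds.

Measured so far:
compound 1, `CCCCNc1nc(N)nc2c1CCN(C(C)=O)C2`: 0.4 uM
compound 2, `CCCCNc1nc(N)nc2c1CN(S(C)(=O)=O)CC2`: 9.9 uM

Both compounds were tested in an assay on HEK293 cells for agonist activity at Toll-like receptor 8 (Homo sapiens), read by a luciferase reporter, with a stated time of 6 h; a higher number here means that more compound is needed for the effect, a lower number that less compound is needed. Compound 1 gives 0.4 uM, while compound 2 gives 9.9 uM. Of these two numbers, compound 2 stands at the top: it needs the larger amount of compound, and its distance from compound 1 lies beyond the scatter of repeated measurements. The two compounds differ in more than one place, so their values can only be read as a pair of results and not traced to a single change.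

Compound 3, `CCCCNc1nc(N)nc2c1CN(C(=O)CC)CC2`, keeps the shared core and the butylamino side chain of compound 2 and alters one group: propanoyl in place of methylsulfonyl on an amine nitrogen in a ring. For the measured compounds named here, no measured pair shows this change on its own, so its effect can only be expected, not read off. The expectation is a moderate move toward a lower number, an estimated step of a 6.6-fold lower number from compound 2 to compound 3 (0.82 log units; beyond the scatter). For compound 3 in this assay the estimate is 1.5 uM, with a likely range from 0.3 uM to 6 uM.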

Compound 3, minimum effective concentration: 0.4 uM
Beside the measured number, compound 3's estimate is 3.8-fold (0.57 log units) above it; the measured number falls inside the stated range.
By their numbers in this assay, from the lowest: compounds 1 and 3 (each within the scatter of the next); then compound 2.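

Exchanging methylsulfonyl for propanoyl on an amine nitrogen in a ring gives a 25-fold lower number from compound 2 to compound 3 (1.39 log units; beyond the scatter) in this assay, so what sits on this nitrogen clearly matters in this series. The step comes without any change in the heavy-atom count of the group, which means that count alone does not separate the two; the groups differ instead in their atoms, with carbon and a single double bond in propanoyl, against sulfur and two double bonds in methylsulfonyl, and in their hydrogen-bond acceptor counts. Nothing measured here accounts for the size of this step, and the reason for it remains unknown.

The compounds shown leave open which part of propanoyl goes with the lower number, the carbonyl or the carbon chain attached to it, and a comparison with ethylsulfonyl or a longer acyl chain such as butanoyl on the same nitrogen would help to separate the two. On these data alone, it also remains open how a plain secondary amine, with only a hydrogen on that nitrogen, would behave.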